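This account rests on a few compounds, and the source may have more. Where it says the series, first, only, none or still open, it means among the compounds named here.

Measured compounds in a functional assay on MDA-MB-435S cells (Homo sapiens) for cytotoxicity, read by MTT assay, with a stated time of 72 h; on this read-out higher numbers stand for weaker inhibition and lower numbers for stronger inhibition:
Compound 1 `Cc1nnc(Sc2coc3ccccc3c2=O)s1` gives > 50000 nM, which is a limit of the assay.
Compound 2 `Cc1nnc(SCc2coc3ccc(Cl)cc3c2=O)o1` gives 3300 nM.
Compound 3 `Cc1nnc(SCc2cc(=O)c3ccccc3o2)s1` gives > 25000 nM, again a limit of the assay and not a number.

Compound 3 therefore stands without a measured number in this assay: its result sits at the limit of > 25000 nM in this assay, at which 1 of the 3 values shown sits, and only compound 2 among the three carries a real value, while compound 1 sits at the limit of > 50000 nM in this assay, at which 1 of the 3 values shown sits. No pair of these compounds differs in a single place, so no measured step can be drawn from them.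

Going by the values given here, compound 4 `Nc1nnc(SCc2cc(=O)c3ccccc3o2)s1` is the one compound still to be measured. It differs from compound 3 in one place: amino in place of methyl on an aromatic carbon, or 5-methyl-1,3,4-thiadiazol-2-yl to 5-amino-1,3,4-thiadiazol-2-yl. Among the compounds with values here, no comparable step exists among the measured compounds, and compound 3 itself offers only a limit as a starting point, so the expectation for this step in this assay is none beyond the usual scatter, with the chance of a weak number rather than a further limit left open. Compound 4 is therefore expected to give 40000 nM in this assay, with a range from 8000 nM to 200000 nM, which means an estimated step that the limit leaves unreadable from compound 3 to compound 4.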

Compound 4, half-maximal inhibitory concentration: > 25000 nM
Compound 4: a limit, no number; the forecaster's own chance of this, stated with the estimate: 70%; the middle value does not contradict the limit.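

In this assay compound 4 gives > 25000 nM, a limit of the assay and not a number. Compound 3 gives > 25000 nM, also a limit, so no step can be read between compound 3 and compound 4. The compounds shown leave open whether amino in place of methyl on an aromatic carbon changes the result in this assay at all.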